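Replacing the Hydroxy Group with a Methoxy-Bearing Branch

The source may hold more compounds than are shown below. What is called first, only, known or untested is meant among the compounds shown, and "the series" means these compounds.

Measured compounds:
compound 1 `COCC(C)(C)C#Cc1c(Cl)c2c(Cl)cc(C(N)=O)nc2n1[C@H]1CCCNC1`: 219 nM
compound 2 `NC(=O)c1cc(Cl)c2c(Cl)c(C#CCO)n([C@H]3CCCNC3)c2n1`: 301 nM
compound 3 `NC(=O)c1cc(Cl)c2c(Cl)c(C#CC3CCCO3)n([C@H]3CCCNC3)c2n1`: 223 nM; 91 nM (2 entries)

All three share one core and differ only in the group attached to the triple bond. In a functional assay on KG-1 cells (Homo sapiens) for antiproliferative activity (on this read-out higher numbers stand for an effect only at larger amounts of compound and lower numbers for an effect already at smaller amounts), compound 2 gives 301 nM; the nearest number is that of compound 1, and the step of a 1.4-fold higher number from compound 1 to compound 2 (0.14 log units; within the scatter) stays within the scatter. Compound 3 has several entries in this assay the several entries of compound 3 in this assay, 223 nM; 91 nM (2 entries) and so carries no single number.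

Compound 4 `COC(C)(C)CC#Cc1c(Cl)c2c(Cl)cc(C(N)=O)nc2n1[C@H]1CCCNC1` differs from compound 2 by 1-methoxy-1-methylethyl in place of hydroxy on a saturated chain carbon bound to a triple-bonded carbon. For the measured compounds named here, the one measured step, a 1.4-fold higher number from compound 1 to compound 2 (0.14 log units; within the scatter), exchanged a related ether-bearing branch for hydroxymethyl without leaving the scatter, so the change to compound 4 is expected to produce no step beyond the scatter, a 1.4-fold lower number from compound 2 to compound 4 (0.14 log units; within the scatter). Compound 4 is therefore estimated at 220 nM, ranging from 90 nM to 550 nM.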

Compound 4, half-maximal effective concentration: 172 nM
Beside the measured number, compound 4's estimate is 1.3-fold (0.11 log units) above it; low and high end bracket the measured number.
By their numbers in this assay, from the lowest: compounds 4, 1 and 2 (each within the scatter of the next).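

In this assay, the hydroxy group and its hydrogen-bond donor can give way to the larger 1-methoxy-1-methylethyl branch on a saturated chain carbon bound to a triple-bonded carbon, giving a 1.8-fold lower number from compound 2 to compound 4 (0.24 log units; within the scatter). Exchanging 1-(methoxymethyl)-1-methylethyl for 2-methoxy-2-methylpropyl on a triple-bonded carbon likewise gives a 1.3-fold lower number from compound 1 to compound 4 (0.10 log units; within the scatter), so rearranging the ether-bearing branch also stays within the scatter. Nothing measured here bears on the reason for these results. On these data alone, whether an amine, a carboxylic acid or a longer chain at this place would produce a step beyond the scatter remains open.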